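The source may hold more compounds than are shown below. What is called first, only, known or untested is meant among the compounds shown, and "the series" means these compounds.

Measured compounds:
Compound 1 `O=C1N/C(=N/c2ccccc2F)S/C1=C\c1ccc(C(=O)O)cc1` — 8000 nM
Compound 2 `O=C(Nc1cc(F)cc2c(=O)cc(C(=O)O)oc12)c1ccc(Cl)c(Cl)c1` — 2650 nM
Compound 3 `CCCOc1ccc(C(=O)Nc2cccc3c(=O)cc(C(=O)O)oc23)cc1` — 3610 nM

The three compounds were tested in an assay on CHO cells for agonist activity at G protein-coupled receptor GPR35 (Rattus norvegicus), read by a beta-galactosidase reporter and beta-arrestin recruitment, with a stated time of 90 min; a lower number here means that less compound is needed, a higher number that more compound is needed for the effect. Compound 2 has the lowest of the three numbers. Compound 3 sits nearest to it, and the gap between the two is within the scatter of the assay, so no order between compound 2 and compound 3 can be read from these values. Compound 1 lies furthest from compound 2, and that gap is beyond the scatter.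

Compound 4 `O=C(Nc1cc(Br)cc2c(=O)cc(C(=O)O)oc12)c1ccc(Cl)c(Cl)c1` has not yet been measured. It departs from compound 2 in a single place: bromo in place of fluoro on an aromatic carbon. The exchange is a halogen for a halogen, one heavy atom for one heavy atom, with no change in ring count, hydrogen-bond donors, hydrogen-bond acceptors or net charge.

Among the compounds with values here, no pair among the measured compounds differs in only one place, so there is no measured step to lean on here. For this assay the author expects a small step, if any, from compound 2 to compound 4, most likely within the scatter, with a slight lean toward a lower number. The estimate for compound 4 is 2000 nM, with a range from 700 nM to 6000 nM, which corresponds to an expected step of a 1.3-fold lower number from compound 2 to compound 4 (0.12 log units; within the scatter).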

Compound 4, half-maximal effective concentration: 3250 nM
Estimate against measurement, compound 4: 1.6-fold (0.21 log units) below; the range from low to high includes it.
By their numbers in this assay, from the lowest: compounds 2, 4 and 3 (each within the scatter of the next); then compound 1.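

In this assay, the exchange of fluoro for bromo gives a 1.2-fold higher number from compound 2 to compound 4 (0.09 log units; within the scatter), so the two compounds cannot be told apart by this read-out. This is the first pair shown that differs in only one place, and it indicates that this aromatic carbon, meta to a large group and para to a fused ring, tolerates either halogen without a readable difference, even though bromo and fluoro are different atoms. Nothing among the data shown explains this result, so it stands as an observation for this single pair alone.

As far as these compounds go, whether an amine or a methoxy group on this aromatic carbon would give a step beyond the scatter remains open, as does the result with plain hydrogen or with chloro there. Also open, from the compounds shown here alone, is whether the exchange of fluoro for bromo would read the same way in a compound carrying a propoxy group in place of the two chloro groups, since this single pair cannot show how far the result extends.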